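Thiosemicarbazones on HeLa cells: a swap on the aryl nitrogen

The source may hold more compounds than are shown below. What is called first, only, known or untested is meant among the compounds shown, and "the series" means these compounds.

Compound 1 `S=C(N/N=C/c1ccc2ccccc2n1)Nc1cccc(Cl)c1`: 52500 nM
Compound 2 `CN(C)C(=S)N/N=C/c1cnc2ccccc2n1`: 750 nM

In a functional assay on HeLa cells (Homo sapiens) for antiproliferative activity, read by sulforhodamine B assay, with a stated time of 72 h (a higher number here means a weaker inhibitor, a lower number a stronger inhibitor), compound 1 gives 52500 nM, the highest of the two numbers, while compound 2 gives 750 nM, a gap between the two that lies beyond the scatter. Compound 3 `Cc1ccc(NC(=S)N/N=C/c2ccc3ccccc3n2)cc1` differs from compound 1 in one place: 4-methylphenyl in place of 3-chlorophenyl on an amide-type nitrogen. Among the measured compounds shown here, no measured pair shows this change, so nothing here tells its size or direction. The step from compound 1 to compound 3 is expected to stay within the scatter: a 1.1-fold lower number from compound 1 to compound 3 (0.02 log units; within the scatter). For compound 3 the estimate in this assay is 50000 nM, with a range from 15000 nM to 150000 nM.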

Compound 3, half-maximal inhibitory concentration: 86000 nM
Estimate against measurement, compound 3: 1.7-fold (0.24 log units) below; the measured number falls inside the stated range.
By their numbers in this assay, from the lowest: compound 2; then compounds 1 and 3 (each within the scatter of the next).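

In this assay, 4-methylphenyl in place of 3-chlorophenyl on the amide-type nitrogen gives a 1.6-fold higher number from compound 1 to compound 3 (0.21 log units; within the scatter). This first pair at this position shows that the two aryl groups cannot be told apart by this read-out, so the swap leaves the number where it was within the scatter. Nothing at hand bears on why this is so.

On these data alone, whether a phenyl carrying an amine or a carboxylic acid, or a longer chain in place of the aryl group, would shift the number at this nitrogen stays open. So does whether these two aryl groups would also match on the core of compound 2.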